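A Chloro Added Where Compound 3 Sits at the Limit

The source may hold more compounds than are shown below. What is called first, only, known or untested is meant among the compounds shown, and "the series" means these compounds.

Three measured compounds share one core. In a functional assay on SW480 cells (Homo sapiens) for antiproliferative activity, read by MTT assay, with a stated time of 72 h (a lower number here means a stronger inhibitor, a higher number a weaker inhibitor), compound 1 `O=c1c(SC(=S)N2CCCCC2)coc2ccccc12` gives 16300 nM. Compound 2 `CCOC(=O)c1cc(=O)c2cc(CSC(=S)N3CCCCC3)ccc2o1` is reported in this assay only as a limit, > 25000 nM. Compound 3 `O=c1c(SC(=S)N2CCCC2)coc2ccccc12` likewise reaches only a limit in this assay, > 25000 nM, so among the numbers shown it stands at an edge rather than at a value; the limit of > 25000 nM in this assay, at which 2 of the 3 values shown sit, marks that edge. Going by the values given here, the one measured step, an at least 1.5-fold higher number from compound 1 to compound 3 (0.18 log units; that floor lies within the scatter), changes only the amine. Compound 4 `O=c1c(SC(=S)N2CCCC2)coc2ccc(Cl)cc12` differs from compound 3 by chloro in place of hydrogen on an aromatic carbon. Among the compounds with values here, no measured step involves a chloro on the ring, so no direction can be read from the data. The step of a number no higher from compound 3 to compound 4 (the limit leaves the size open) is expected to stay within the scatter. Compound 4 is estimated at 25000 nM, between 9000 nM and 70000 nM.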

Compound 4, half-maximal inhibitory concentration: > 25000 nM
Compound 4: no number, only a limit; the forecaster's own chance of this, stated with the estimate: 65%; the middle value lies on the limit itself.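

Compound 3 and compound 4 each reach only a limit in this assay, so no step can be read between them: the limit of > 25000 nM in this assay, at which 3 of the 4 values shown sit. From the compounds shown here alone, whether chloro in place of hydrogen on an aromatic carbon changes the activity of compound 3 stays open.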